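Changing the aryl group on the five-membered ring: compound 4

The source may report more compounds than this note shows. Statements on the series, on what has been measured and on what is new or still open speak of the compounds shown alone.

Compound 1 `Cc1cc(NC(=O)Cn2nnc(-c3ccccc3)n2)n(C2CCC(C)(C)CC2)n1` is shown in an assay on HEK293 cells for activation of Kir3.1/Kir3.2 (Homo sapiens), read by thallium flux (on this read-out lower numbers stand for smaller maximal responses and higher numbers for larger maximal responses), only as a limit, > 19%. Compound 2 `Cc1cc(NC(=O)Cn2nnc(-c3ccccn3)n2)n(C2CCCCC2)n1` gives 81% in this assay. Compound 3 `Cc1cc(NC(=O)Cn2nnc(-c3ccnc(F)c3)n2)n(C2CCCCC2)n1` gives 95% in this assay. Compound 4 `Cc1cc(NC(=O)Cn2nnc(-c3cccc(C(F)(F)F)c3)n2)n(C2CCCCC2)n1` has not yet been measured.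

Among the two numbers shown, compound 3 holds the higher one; compound 2 stands nearest, and the gap to it, a number 14 percentage points higher from compound 2 to compound 3 (beyond the scatter), lies beyond the scatter. Compound 1 sits at a limit of the assay, (the limit of > 19% in this assay, at which 1 of the 3 values shown sits), and does not enter this comparison.

Compound 4 differs from compound 3 in one place: 3-(trifluoromethyl)phenyl in place of 2-fluoropyridin-4-yl on an aromatic carbon. For the measured compounds named here, the only measured step that bears on such a change of the aryl group is the one from compound 2 to compound 3, a modest rise of a number 14 percentage points higher from compound 2 to compound 3 (beyond the scatter). Compound 1, with a phenyl group on the same carbon but a different ring on the nitrogen, gives only a limit and offers no number. Going by the values given here, with one modest step as the sole guide, and the rings differing in kind this time, a change no larger than that step is expected in either direction, most likely a small fall. Compound 4 is therefore estimated at 82%, between 55% and 105%, an expected step of a number 13 percentage points lower from compound 3 to compound 4 (beyond the scatter).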

Compound 4, largest response reached (Emax), in percent of the reference or control that the assay uses: 86%
For compound 4 the middle estimate is 4 percentage points below the measured one, within the range that was stated.
By their numbers in this assay, from the lowest: compounds 2, 4 and 3 (each within the scatter of the next, the first and the last beyond it).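

In this assay compound 4 shows that the aromatic carbon between two ring nitrogen atoms tolerates a ring of carbon only, so a ring nitrogen in the aryl group is not needed there for a large maximal response. Replacing 2-fluoropyridin-4-yl gives a number 9 percentage points lower from compound 3 to compound 4 (within the scatter) and replacing pyridin-2-yl gives a number 5 percentage points higher from compound 2 to compound 4 (within the scatter) despite the larger group, which has no hydrogen-bond acceptor. The data given offer no explanation for how closely these aryl groups read.

As far as these compounds go, it remains open how an aryl ring carrying a basic amine or a carboxylic acid would behave at this carbon. It is also open whether trifluoromethyl itself matters, since a plain phenyl group is shown only on compound 1, which has a different ring on the nitrogen.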